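This account rests on a few compounds, and the source may have more. Where it says the series, first, only, none or still open, it means among the compounds named here.

Compound 1 `COc1ccc(C#Cc2ccc(C(=O)N3CCCC(C)(O)C3)cc2)cc1`, compound 2 `COc1ccc(C#Cc2ccc(C(=O)N3CC[C@@H](O)C3)cc2)cc1` and compound 3 `COc1ccc(C#Cc2ccc(C(=O)N3CCC[C@@H](O)C3)cc2F)cc1` share one core and differ in the hydroxy-bearing saturated ring on the amide and in the substitution of the central ring. In a functional assay on HEK293 cells for negative allosteric modulation of metabotropic glutamate receptor 2 (Rattus norvegicus), read by calcium flux, with a stated time of 2.5 min (a lower number here means a stronger inhibitor, a higher number a weaker inhibitor), compound 1 gives only a limit of the assay, > 30000 nM. In this assay compound 2 likewise returns only a limit, > 30000 nM. In this assay compound 3 also stands at a limit, > 30000 nM. Going by the values given here, the single step between compounds differing in one place, a step that the two limits leave unreadable from compound 1 to compound 2, is therefore of unreadable size, and the picture is summed up by the limit of > 30000 nM in this assay, at which 3 of the 3 values shown sit. Compound 4 `COc1ccc(C#Cc2ccc(C(=O)N3CC[C@H](O)C3)cc2)cc1` is the unmeasured partner of compound 2: the two compounds have the same atoms and bonds and differ only in configuration as drawn: 1 of 1 stereo elements differ; a stereocentre at a saturated ring carbon is drawn R in compound 2 and S in compound 4. Among the compounds with values here, no measured step bears on a change of configuration alone, and the only step on record, from compound 1 to compound 2, gives no size at all. With compound 2 at a limit and every neighbour at the same limit, compound 4 is expected to sit there too, and the step of a number no higher from compound 2 to compound 4 (the limit leaves the size open) is expected to stay within the scatter. Compound 4 is therefore estimated at 30000 nM in this assay, with a range from 10000 nM to 100000 nM, and most likely only a limit will be reported.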

Compound 4, half-maximal inhibitory concentration: > 30000 nM
Compound 4: no number, only a limit (the forecaster's own chance of this, stated with the estimate: 80%); the middle value sits exactly at the limit.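

In this assay compound 4 returns only a limit, as do compound 1 and compound 2, and the steps from compound 1 and compound 2 to compound 4 cannot be read. The compounds shown leave open whether configuration alone changes inhibition, and how any of these compounds compares with another: the limit of > 30000 nM in this assay, at which 4 of the 4 values shown sit.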